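Ethoxy for Ethyl on the Carbonyl: Solubility Notes

The source may hold more compounds than are shown below. What is called first, only, known or untested is meant among the compounds shown, and "the series" means these compounds.

Compound 1 `CCC(=O)c1cc(-c2ccccc2Cl)n(-c2ccc(S(N)(=O)=O)cc2)c1C` carries a propanoyl group on its core; in a physicochemical assay for solubility, read by HPLC, in phosphate buffer, measured as kinetic solubility, at pH 7.4 (on this read-out lower numbers stand for lower solubility and higher numbers for higher solubility), compound 1 gives 38200 nM. Compound 2 `CCOC(=O)c1cc(-c2ccccc2Cl)n(-c2ccc(S(N)(=O)=O)cc2)c1C` differs from it by ethoxy in place of ethyl on a carbonyl carbon and in this assay compound 2 gives 13700 nM, a step of a 2.8-fold lower number from compound 1 to compound 2 (0.45 log units; beyond the scatter). Compound 3 `CCC(=O)c1cc(-c2ccc(F)cc2)n(-c2ccc(S(N)(=O)=O)cc2)n1` stands on a different core; how the two cores differ is not broken down here. In this assay compound 3 gives 88900 nM, the highest of the three measured numbers. Compound 4 `CCOC(=O)c1cc(-c2ccc(F)cc2)n(-c2ccc(S(N)(=O)=O)cc2)n1` is not yet measured and differs from compound 3 by ethoxy in place of ethyl on a carbonyl carbon, the same change at the same place as between compound 1 and compound 2. For the measured compounds named here, the step from compound 3 to compound 4 is expected to be about a 2.8-fold lower number from compound 3 to compound 4 (0.44 log units; beyond the scatter), resting on the single measured example of this change, a 2.8-fold lower number from compound 1 to compound 2 (0.45 log units; beyond the scatter). Compound 4 is therefore estimated at 32000 nM in this assay, with a likely range from 16000 nM to 64000 nM.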

Compound 4, solubility: 56400 nM
Compound 4: the middle estimate sits 1.8-fold (0.25 log units) below what was measured, within the range that was stated.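

In this assay ethoxy in place of ethyl on a carbonyl carbon gives a 1.6-fold lower number from compound 3 to compound 4 (0.20 log units; within the scatter) on the core of compound 3 and a 2.8-fold lower number from compound 1 to compound 2 (0.45 log units; beyond the scatter) on the core of compound 1. The pair on the core of compound 3 is not separated beyond the usual scatter, and two pairs fix no size for this change on any further core. Nothing measured here bears on why the step reads differently on the two cores.

Still open, on these data alone, is how other groups on this carbonyl carbon would read, such as an amine forming the amide, a carboxylic acid, or a longer chain such as butoxy. As far as these compounds go, whether either step holds on a third core is also open.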